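Shortening the chain on the core of compound 1

The source may report more compounds than this note shows. Statements on the series, on what has been measured and on what is new or still open speak of the compounds shown alone.

Compound 1 `CCCCCCCCNc1nccnc1C(=O)NCc1ccccc1` carries the longer saturated chain on its core. In an ADME assay on HeLa cells (Homo sapiens) for cytotoxicity, read by microscopy, with a stated time of 6 days (on this read-out lower numbers stand for higher toxicity in this test and higher numbers for lower toxicity in this test), compound 1 gives > 100000 nM, which is a limit of the assay and not a number. Compound 4 `CCCCCCNc1nccnc1C(=O)NCc1ccccc1` differs from compound 1 by hydrogen in place of ethyl on a saturated chain carbon, six bonds along the chain from a nitrogen on an aromatic ring. Among the compounds with values here, the only measured pair that bears on this change is the reverse change on the other core, between compound 2 `CCCCCCNc1cnc(C(=O)NCc2ccccc2)cn1` and compound 3 `CCCCCCCCNc1cnc(C(=O)NCc2ccccc2)cn1`. In this assay compound 2 gives > 100000 nM, again a limit. In this assay compound 3 gives 100000 nM. That step, a number no higher from compound 2 to compound 3 (the limit leaves the size open), leaves its size open, since the limit of > 100000 nM in this assay, at which 2 of the 3 values shown sit, holds two of the three values seen. Within the data shown here, no other pair speaks to the change, so no direction can be read for it. The expectation is therefore a number no higher from compound 1 to compound 4 (the limit leaves the size open), nothing beyond the scatter as far as the series shows. Compound 4 is estimated at 100000 nM, within 50000 nM to 300000 nM, and most likely reported once more as a limit.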

Compound 4, minimum cytotoxic concentration: > 100000 nM
Compound 4: a limit, no number; the forecaster's own chance of this, stated with the estimate: 85%; the middle value sits exactly at the limit.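

In this assay compound 1 and compound 4 both stand as limits, not numbers, so no step between them can be read: the limit of > 100000 nM in this assay, at which 3 of the 4 values shown sit.

The compounds shown leave open what hydrogen in place of ethyl does on the core of compound 1, since no number is available on that core.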